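Fluoro for methyl on the anilino ring of compound 2

A few compounds are considered here, and "the series" means these few. Any claim that something is new, unique, unknown or untested is made for them only; others in the source may bear on it.

Compound 2 `COC(=O)c1c(Nc2ccc(C)cc2)sc(C(=O)c2ccc(C)cc2)c1C` was tested in a functional assay, with a stated time of 150 min, tested at 10 ug/mL (a higher number here means a stronger effect of the compound at the concentration tested, a lower number a weaker effect), but returned no number: compound 2 was reported as "not active" (no number reported), so it stands below anything measurable here. A related compound 1 `COC(=O)c1c(Nc2ccc(F)cc2)sc(C(=O)c2ccc(OC)cc2)c1C` gives 14% in this assay. Compound 3 `COC(=O)c1c(Nc2ccc(F)cc2)sc(C(=O)c2ccc(C)cc2)c1C` has not been measured. It differs from compound 2 in one place: fluoro in place of methyl on an aromatic carbon. For the measured compounds named here, no measured step exists for this change, so one expects only a small rise in this assay, likely within the usual scatter, because compound 2 is reported as "not active" (no number reported) and compound 1 reaches just 14%. For compound 3 in this assay one estimates 10%, between 0% and 25%.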

Compound 3, a percentage reported as activity, at one concentration (the size of the read-out at that concentration, not a potency): "not active" (no number reported)
Compound 3: no number reported; no gap can be computed for the estimate.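

In this assay compound 2 gives "not active" (no number reported) and compound 3 gives "not active" (no number reported), so no step can be read between them. The compounds shown leave open whether swapping methyl for fluoro changes this effect at all. Nothing available here bears on this result.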